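Notes on the series: from compound 2 toward compound 4

A few compounds are considered here, and "the series" means these few. Any claim that something is new, unique, unknown or untested is made for them only; others in the source may bear on it.

Measured compounds:
compound 1: `O=C(COc1ccc(C(=O)/C=C/c2ccccc2Cl)cc1)N[C@H]1CCOC1=O`; in a functional assay on MGC-803 cells (Homo sapiens) for antiproliferative activity, read by MTT assay, with a stated time of 72 h (a higher number here means a weaker inhibitor, a lower number a stronger inhibitor), compound 1 gives 27100 nM.
compound 2: `COc1ccccc1/C=C/C(=O)c1ccc(OCC(=O)N[C@H]2CCOC2=O)cc1`; in this assay compound 2 gives 39400 nM.
compound 3: `O=C(CNc1ccc(Cl)cc1Cl)N[C@H]1CCOC1=O`; in this assay compound 3 gives > 64000 nM, which is a limit of the assay and not a number.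

Among the compounds with values here, compound 2 has the higher of the two numbers, but the one step that leads to it, a 1.5-fold higher number from compound 1 to compound 2 (0.16 log units; within the scatter), is within the scatter, so compound 1 and compound 2 are not separated. Compound 4, `O=C(COc1ccc(C(=O)/C=C/c2cccc(Br)c2)cc1)N[C@H]1CCOC1=O`, differs from compound 2 by 3-bromophenyl in place of 2-methoxyphenyl on a double-bonded chain carbon bound to a double-bonded chain carbon. Within the data shown here, the only measured step that alters this aryl ring is the one from compound 1 to compound 2, and it stayed within the scatter. The move to compound 4 again exchanges groups on this ring, and nothing measured points to a step in this assay beyond the scatter in either direction. Compound 4 is therefore expected near 30000 nM, in the range 12000 nM to 75000 nM. The expected step of a 1.3-fold lower number from compound 2 to compound 4 (0.12 log units; within the scatter) is within the scatter.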

Compound 4, half-maximal inhibitory concentration: 11900 nM
Compound 4: middle estimate off by 2.5-fold (0.40 log units), on the high side, outside the stated range (below it).
By their numbers in this assay, from the lowest: compound 4; then compounds 1 and 2 (each within the scatter of the next). At a limit, above all of these: compound 3.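

In this assay the aryl group on this double-bonded chain carbon does shift the number: a 3.3-fold lower number from compound 2 to compound 4 (0.52 log units; beyond the scatter) and a 2.3-fold lower number from compound 1 to compound 4 (0.36 log units; beyond the scatter) both lie beyond the scatter, unlike a 1.5-fold higher number from compound 1 to compound 2 (0.16 log units; within the scatter) within it. Compound 4 thus stands apart from compound 1 and compound 2 with 3-bromophenyl at this place, though only modestly, and the comparison with compound 1 changes both the halogen and its ring position at once. Nothing measured here accounts for either step.

As far as these compounds go, whether the lower number follows the bromine or its place on the ring stays open, and a 3-chlorophenyl or 2-bromophenyl compound would separate the two. Also open, from the compounds shown here alone, is how an amine or a carboxylic acid on this aryl ring would read in this assay against these halogen and methoxy groups.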